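The source may hold more compounds than are shown below. What is called first, only, known or untested is meant among the compounds shown, and "the series" means these compounds.

Series notes. Among the compounds with values here, in an assay on HEK-293T cells for inhibition of diacylglycerol lipase-alpha (Homo sapiens), read by colorimetric assay (on this read-out lower numbers stand for stronger inhibition and higher numbers for weaker inhibition), compound 2 `O=C(CCCCCCc1ccccc1)c1nc(-c2cccs2)no1` gives 1950 nM, the only number measured so far. Compound 1 `COc1ccc(-c2cnc(C(=O)CCCCCCc3ccccc3)o2)nc1` stands at the limit of this assay with > 10000 nM, which is a limit and not a number (the limit of > 10000 nM in this assay, at which 1 of the 2 values shown sits). Within the data shown here, no step between measured compounds is available. Compound 3 `O=C(CCCCCCc1ccccc1)c1nc(-c2cccc(I)n2)no1` carries 6-iodopyridin-2-yl in place of thiophen-2-yl on an aromatic carbon. The expected step from compound 2 to compound 3 in this assay is a 1.3-fold lower number from compound 2 to compound 3 (0.11 log units; within the scatter), which lies within the usual scatter of repeated measurements. Compound 3 is therefore expected to give about 1500 nM in this assay, with a range from 300 nM to 8000 nM.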

Compound 3, half-maximal inhibitory concentration: > 10000 nM
Compound 3 gave a limit, no number (the forecaster's own chance of this, stated with the estimate: 15%); middle value at least 6.6-fold (0.82 log units) from the limit.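

In this assay, within the data shown here, the aromatic carbon between two ring nitrogen atoms does not tolerate every aromatic ring: 6-iodopyridin-2-yl in place of thiophen-2-yl gives an at least 5.1-fold higher number from compound 2 to compound 3 (0.70 log units; beyond the scatter) and leaves compound 2 as the only compound here with a number. From the compounds shown here alone, the true size of this step stays unknown, since compound 3 sits at a limit and not at a number: the limit of > 10000 nM in this assay, at which 2 of the 3 values shown sit.

Going by these compounds, how a plain pyridin-2-yl or a phenyl would read at this position stays open, so the part played by the iodine cannot be separated from that of the six-membered ring.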